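The compounds below may be only part of what the source reports. "The series", "measured", "known", "first", "only" and "open" are said of these compounds alone.

Measured compounds: compound 1 `Cc1cc(O)cc(-c2nn(CC#N)cc2-c2ccnc(-c3ccc(Oc4ccccc4)cc3)c2)c1` with 82% in a functional assay on OVCAR-5 cells (Homo sapiens) for cytotoxicity, read by sulforhodamine B assay, with a stated time of 48 h, tested at 100 nM (a lower number here means a stronger effect, a higher number a weaker effect of the compound at the concentration tested), and compound 2 `COc1cc(C)cc(-c2nn(CC#N)cc2-c2ccnc(-c3ccc(N(C)C)cc3)c2)c1` with 79% in this assay.

Compound 2 and compound 1 give values that lie within the usual scatter of each other, so neither stands apart. Compound 3 `Cc1cc(O)cc(-c2nn(CC#N)cc2-c2ccnc(-c3ccc(N(C)C)cc3)c2)c1` has not yet been measured. It differs from compound 2 by hydrogen in place of methyl on an oxygen on an aromatic ring. No step between measured compounds is known, so the account can only reason from the two values shown. Since compound 1 already carries the hydroxy group and gives 82%, the step of a number 1 percentage points higher from compound 2 to compound 3 (within the scatter) is expected to stay within the scatter. Compound 3 is therefore estimated at 80%, in the range 66% to 92%.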

Compound 3, a percentage reported as activity, at one concentration (the size of the read-out at that concentration, not a potency): 97%
Beside the measured number, compound 3's estimate is 17 percentage points below it; measured number above the stated range.
By their numbers in this assay, from the lowest: compounds 2 and 1 (each within the scatter of the next); then compound 3.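

In this assay, hydrogen in place of methyl on the oxygen gives a number 18 percentage points higher from compound 2 to compound 3 (beyond the scatter) and so a weaker effect, which shows that methoxy to hydroxy at this position is not a neutral change when dimethylamino is present. With the hydroxy group held fixed, dimethylamino in place of phenoxy gives a number 15 percentage points higher from compound 1 to compound 3 (beyond the scatter) and also weakens the effect. No measured evidence here accounts for either step. The compounds shown leave open how an ethoxy group or an amine at this position would read, and how the methoxy compound with phenoxy would compare.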